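The source may report more compounds than this note shows. Statements on the series, on what has been measured and on what is new or still open speak of the compounds shown alone.

Compound 1 `CC1(C[C@@H](O)C(=O)N2[C@@H]3C[C@@H]3C[C@H]2C(=O)NCc2cc(Cl)ccc2-n2cnnn2)CC1` was run in a functional assay on a cell-free system (plasma, Homo sapiens), with a stated time of 3 min (on this read-out higher numbers stand for weaker inhibition and lower numbers for stronger inhibition), where compound 1 gives 1300 nM. Its companion, compound 2 `CC1(C[C@@H](O)C(=O)N2N=CC[C@H]2C(=O)NCc2cc(Cl)ccc2-n2cnnn2)CC1`, gives 730 nM in this assay; the two numbers lie within the usual scatter of each other, so neither stands apart. Compound 3 `O=C(NCc1cc(Cl)ccc1-n1cnnn1)[C@@H]1C[C@H]2C[C@H]2N1C(=O)[C@H](O)c1cccc(F)c1` has not yet been measured. It differs from compound 1 in one place: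

3-fluorophenyl in place of (1-methylcyclopropyl)methyl on a saturated chain carbon bound to a carbonyl carbon and an oxygen on a saturated carbon

For the measured compounds named here, no measured pair shows what such a change does, so the expectation rests on the values alone. In this assay the change is expected to give a 1.4-fold lower number from compound 1 to compound 3 (0.16 log units; within the scatter), no step beyond the scatter in either direction. Compound 3 is accordingly estimated at 900 nM, within a range from 250 nM to 3500 nM.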

Compound 3, half-maximal inhibitory concentration: 1100 nM
For compound 3 the middle estimate is 1.2-fold (0.09 log units) below the measured one; the range from low to high includes it.
By their numbers in this assay, from the lowest: compounds 2, 3 and 1 (each within the scatter of the next).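

Putting 3-fluorophenyl in place of (1-methylcyclopropyl)methyl on this saturated chain carbon gives a 1.2-fold lower number from compound 1 to compound 3 (0.07 log units; within the scatter) in this assay. This position therefore carries either a six-membered aromatic ring or a three-membered saturated one, and on the core of compound 1 this read-out does not tell the two groups apart. No supporting measurement speaks to what lies behind this result. Still open, as far as these compounds go, is whether an amine or a carboxylic acid at this carbon would give a step beyond the scatter. Also open, from the compounds shown here alone, is what a plain phenyl, without its fluorine, would give.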